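Trading 2-Ethoxyphenyl for 3-Fluorophenyl

A few compounds are considered here, and "the series" means these few. Any claim that something is new, unique, unknown or untested is made for them only; others in the source may bear on it.

In a functional assay, with a stated time of 6 min (a lower number here means a stronger inhibitor, a higher number a weaker inhibitor), compound 1 `S=c1[nH]nc(-c2ccc3c(c2)OCCO3)o1` gives 10600 nM. Compound 2 `CCOc1ccccc1NCn1nc(-c2ccc3c(c2)OCCO3)oc1=S` gives 5280 nM, which lies within the usual scatter of the value for compound 1, so these two cannot be told apart. Compound 3 `CCCCCCCCCCCCCCCCNCn1nc(-c2ccc3c(c2)OCCO3)oc1=S` gives 22900 nM, a weaker result than compound 2 and beyond the scatter. Compound 4 `Fc1cccc(NCn2nc(-c3ccc4c(c3)OCCO4)oc2=S)c1` has not yet been measured. It carries 3-fluorophenyl in place of 2-ethoxyphenyl on an amine nitrogen. Within the data shown here, no measured pair shows this swap directly, so no change beyond the scatter is expected, and the estimated step is a 1.1-fold higher number from compound 2 to compound 4 (0.06 log units; within the scatter). Compound 4 is expected to give about 6000 nM, with a likely range from 2000 nM to 18000 nM.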

Compound 4, half-maximal inhibitory concentration: 6620 nM
Estimate against measurement, compound 4: 1.1-fold (0.04 log units) below; low and high end bracket the measured number.
By their numbers in this assay, from the lowest: compounds 2, 4 and 1 (each within the scatter of the next); then compound 3.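

In this assay, swapping the group on this amine nitrogen gives a 1.3-fold higher number from compound 2 to compound 4 (0.10 log units; within the scatter) and so leaves 3-fluorophenyl and 2-ethoxyphenyl indistinguishable. At this position, then, the aromatic ring can lose the ethoxy group and gain a fluorine, along with losing the hydrogen-bond acceptor counted in 2-ethoxyphenyl, without a change beyond the scatter. No measurement is available to explain this result. Still open, as far as these compounds go, is whether a carboxylic acid or an amine on this aromatic ring would shift the number beyond the scatter.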